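The source may hold more compounds than are shown below. What is called first, only, known or untested is meant among the compounds shown, and "the series" means these compounds.

Working notes on the series. For the measured compounds named here, in an assay on cells for positive allosteric modulation of Cystic fibrosis transmembrane conductance regulator variant F508del (Homo sapiens), with stated times of 10 min and 7 s, in the presence of a further agent that is not named here (a lower number here means that less compound is needed, a higher number that more compound is needed for the effect), compound 2 `CC1(C)Cc2c(sc(NC(=O)c3[nH]ncc3Cl)c2C(N)=O)C(C)(C)O1` gives 2 nM, the lowest of the two numbers so far; compound 1 `CC1(C)Cc2c(sc(NC(=O)C(C)(C)CO)c2C(N)=O)C(C)(C)O1` gives 75 nM, and the step of a 38-fold lower number from compound 1 to compound 2 (1.57 log units; beyond the scatter) shows how much the acyl group at the carbonyl carbon can move the read-out. Compound 3 `CC1(C)Cc2c(sc(NC(=O)c3cc(C(F)(F)F)n[nH]3)c2C(N)=O)C(C)(C)O1` differs from compound 2 by a group of 9 heavy atoms (4 carbon, 2 nitrogen, 3 fluorine; one five-membered aromatic ring with 2 hetero atoms) in place of a group of 6 heavy atoms (3 carbon, 2 nitrogen, 1 chlorine; one five-membered aromatic ring with 2 hetero atoms), on a carbonyl carbon. That step keeps the five-membered aromatic ring and its one donor and one acceptor, so a change far smaller than the step from compound 1 to compound 2 is expected. For compound 3 the expected value is 4 nM (range 1.5 nM to 12 nM), a step of a 2.0-fold higher number from compound 2 to compound 3 (0.30 log units; within the scatter) that is expected to stay within the scatter.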

Compound 3, half-maximal effective concentration: 3 nM
The estimate for compound 3 lay 1.3-fold (0.12 log units) above the measured number; low and high end bracket the measured number.
By their numbers in this assay, from the lowest: compounds 2 and 3 (each within the scatter of the next); then compound 1.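

In this assay, one five-membered aromatic ring on the carbonyl carbon replaces another, with the larger 3-(trifluoromethyl)-1H-pyrazol-5-yl entering (a 1.5-fold higher number from compound 2 to compound 3 (0.18 log units; within the scatter)), so the three fluorine atoms and the added size leave the number within the scatter. The open chain of compound 1 now compares with two ring groups rather than one, and the second comparison (a 25-fold lower number from compound 1 to compound 3 (1.40 log units; beyond the scatter)) is again large, so the large step is not tied to the group in compound 2. Still open, going by these compounds, is how a six-membered phenyl ring or a carboxylic acid on this carbonyl carbon would read out, and whether the ring hydrogen-bond donor matters. No evidence at hand bears on the reason for these steps.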